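A few compounds are considered here, and "the series" means these few. Any claim that something is new, unique, unknown or untested is made for them only; others in the source may bear on it.

Measured compounds:
compound 1, `C=CCOc1ccc2c(NCCN(C)C)ccnc2c1`, 1660 nM
compound 2, `CCOc1ccc2c(Cl)ccnc2c1`, 2660 nM

Both were tested in a functional assay on HepG2 cells (Homo sapiens) for cytotoxicity, read by MTT assay, with a stated time of 48 h; on this read-out lower numbers stand for stronger inhibition and higher numbers for weaker inhibition. Compound 2 has the higher of the two numbers, but its nearest neighbour, compound 1, sits within the usual scatter of it, so no order between the two can be claimed.

The next compound, compound 3, `CCOc1ccc2c(NCCN(C)C)ccnc2c1`, has not yet been measured. Compared with compound 2, it carries a ((2-(dimethylamino)ethyl)amino in place of chloro on an aromatic carbon). Everything else in the shared core stays the same. Among the measured compounds shown here, no pair of measured compounds differs in this one place, so no measured step shows directly what this change does.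

Compound 1 carries the same (2-(dimethylamino)ethyl)amino group, and in this assay compound 1 gives 1660 nM, a number that lies within the scatter of compound 2. The expectation is therefore a step from compound 2 to compound 3 of a 1.4-fold lower number from compound 2 to compound 3 (0.15 log units; within the scatter), that is, nothing clearly beyond the scatter, if anything a slightly lower number. For compound 3 the estimate in this assay is 1900 nM, with a range from 800 nM to 4500 nM.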

Compound 3, half-maximal inhibitory concentration: 5680 nM
Estimate against measurement, compound 3: 3.0-fold (0.48 log units) below; measured number above the stated range.
By their numbers in this assay, from the lowest: compounds 1 and 2 (each within the scatter of the next); then compound 3.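

In this assay, the first direct test of this swap on the aromatic carbon opposite the ring nitrogen, (2-(dimethylamino)ethyl)amino in place of chloro gives a 2.1-fold higher number from compound 2 to compound 3 (0.33 log units; beyond the scatter), so the larger group, with its added hydrogen-bond donor and acceptors, comes with modestly weaker inhibition in this pair. With that group held fixed, methyl in place of vinyl on the saturated chain carbon bound to the oxygen gives a 3.4-fold higher number from compound 1 to compound 3 (0.53 log units; beyond the scatter), which shows that a small change elsewhere in the molecule shifts the number by a similar modest amount, so the effect of the amino chain should not be judged from one compound alone. Nothing available here explains either step.

The compounds shown leave open whether other groups on the same aromatic carbon, such as a longer aminoalkyl chain, a morpholine or a simple amine, would follow the same direction as (2-(dimethylamino)ethyl)amino. They also leave open how the chloro compound would respond to the methyl-to-vinyl change, and whether a propyl or benzyl group on the oxygen would give lower or higher numbers.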